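Furan series: acetoxymethyl variant of compound 2

This account rests on a few compounds, and the source may have more. Where it says the series, first, only, none or still open, it means among the compounds named here.

Compound 2 `CCc1cccc2c(OC)c(-c3occ(C)c3C(=O)NC)ccc12` carries a methylcarbamoyl group on the shared core. In a functional assay on DU-145 cells (Homo sapiens) for cytotoxicity, read by MTT assay, with a stated time of 72 h (a higher number here means that more compound is needed for the effect, a lower number that less compound is needed), compound 2 gives > 10 ug/mL, which is a limit of the assay rather than a number. Compound 1 `CCCOC(=O)c1c(C)coc1-c1ccc2c(CC)cccc2c1OC` gives > 10 ug/mL, also a limit. Compound 3 `CCc1cccc2c(OC)c(-c3occ(C)c3C(=O)On3nnc4ccccc43)ccc12` gives > 10 ug/mL, again a limit. The steps a step that the two limits leave unreadable from compound 1 to compound 2, a step that the two limits leave unreadable from compound 1 to compound 3 and a step that the two limits leave unreadable from compound 2 to compound 3 therefore remain unreadable in size, since all three values sit at the limit of > 10 ug/mL in this assay, at which 3 of the 3 values shown sit. Compound 4 `CCc1cccc2c(OC)c(-c3occ(C)c3COC(C)=O)ccc12` differs from compound 2 by acetoxymethyl in place of methylcarbamoyl on an aromatic carbon. Within the data shown here, no measured step bears readably on this change; the only indication is that every member so far sits at the limit. Compound 4 is therefore expected to stay near that limit, with the step that the limit leaves unreadable from compound 2 to compound 4 estimated as small. The estimate for compound 4 in this assay is 15 ug/mL, within 5 ug/mL to 40 ug/mL.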

Compound 4, concentration for half-maximal effect: > 10 ug/mL
Compound 4: no number, only a limit; the forecaster's own chance of this, stated with the estimate: 80%; the middle value lies beyond the limit too.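

Compound 4 gives > 10 ug/mL in this assay, which is a limit, so the steps to compound 4 from compound 1 and compound 2 cannot be read: the limit of > 10 ug/mL in this assay, at which 4 of the 4 values shown sit.

Which group on the shared core, if any, gives a readable value in this assay stays open.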